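A few compounds are considered here, and "the series" means these few. Any claim that something is new, unique, unknown or untested is made for them only; others in the source may bear on it.

Measured so far in an ADME assay (liver) for metabolic stability, with Liver microsome (Rattus norvegicus) as the target, using microsomes and NADPH, with a stated time of 30 min, tested at 1 uM; on this read-out higher numbers stand for fast clearance and lower numbers for slow clearance:
- compound 1 `COCC#Cc1cc(C(O)(C(F)(F)F)C(F)(F)F)cnc1N1CCN(S(=O)(=O)c2ccc(N)nc2)CC1`: 399 mL.min-1.g-1
- compound 2 `CC(C)(C)n1cc(-c2cc(C(O)(C(F)(F)F)C(F)(F)F)cnc2N2CCN(S(=O)(=O)c3ccc(N)nc3)CC2)cn1`: 459 mL.min-1.g-1

Compound 2 cannot be ranked against compound 1, as the two values lie within the scatter of each other. Both sit in the same part of the scale in this assay. For the measured compounds named here, the only measured step is a 1.2-fold higher number from compound 1 to compound 2 (0.06 log units; within the scatter), and it comes from exchanging 3-methoxyprop-1-yn-1-yl for 1-(tert-butyl)-1H-pyrazol-4-yl on an aromatic carbon.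

Compound 3 `CS(=O)(=O)Nc1cccc(-c2cc(C(O)(C(F)(F)F)C(F)(F)F)cnc2N2CCN(S(=O)(=O)c3ccc(N)nc3)CC2)c1` carries its change at that same carbon, with 3-(methanesulfonamido)phenyl in place of 1-(tert-butyl)-1H-pyrazol-4-yl (3-(methanesulfonamido)phenyl in place of 1-(tert-butyl)-1H-pyrazol-4-yl on an aromatic carbon). The site is ortho to a large group and two atoms from the ring nitrogen. Going by the values given here, no measured compound holds the entering group, so the evidence is indirect and rests on one step alone. The expectation therefore follows a 1.2-fold higher number from compound 1 to compound 2 (0.06 log units; within the scatter), a change at this carbon that stayed within the scatter. The expected move is a 1.4-fold lower number from compound 2 to compound 3 (0.14 log units; within the scatter), which is no step beyond the scatter, and the lean in direction is weak. For compound 3 the estimate is 330 mL.min-1.g-1, with an expected range of 150 mL.min-1.g-1 to 650 mL.min-1.g-1.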

Compound 3, intrinsic clearance in microsomes: 81 mL.min-1.g-1
The estimate for compound 3 lay 4.1-fold (0.61 log units) above the measured number; measured number outside the range, below it.
By their numbers in this assay, from the lowest: compound 3; then compounds 1 and 2 (each within the scatter of the next).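

In this assay this aromatic carbon, ortho to a large group and two atoms from the ring nitrogen, now proves sensitive to what it carries: 3-(methanesulfonamido)phenyl in place of 1-(tert-butyl)-1H-pyrazol-4-yl gives a 5.7-fold lower number from compound 2 to compound 3 (0.75 log units; beyond the scatter) and, in place of 3-methoxyprop-1-yn-1-yl, gives a 4.9-fold lower number from compound 1 to compound 3 (0.69 log units; beyond the scatter) on the same read-out. The exchange between those two earlier groups had stayed within the scatter, so the site's tolerance seen there does not extend to every group, and both steps point the same way, towards slower clearance. The change from 1-(tert-butyl)-1H-pyrazol-4-yl swaps a five-membered aromatic ring with 2 hetero atoms for a six-membered aromatic ring of carbon only and adds 1 hydrogen-bond donor, but no measurement on hand ties the lower number to either difference or to any other feature of the entering group.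

Open, from the compounds shown here alone, is whether the lower number belongs to the phenyl ring or to the methanesulfonamido group, a question that an unsubstituted phenyl at this carbon would address. Also open, going by these compounds, is whether a carboxylic acid or a primary amide on the phenyl ring would give a similar number.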